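Carbamoyl in place of the aryloxypropyl ether

The source may report more compounds than this note shows. Statements on the series, on what has been measured and on what is new or still open speak of the compounds shown alone.

In a functional assay on PANC-1 cells (Homo sapiens) for inhibition, read by MTT assay, with a stated time of 24 h, tested at 10 uM (on this read-out lower numbers stand for less inhibition and higher numbers for more inhibition at the one concentration tested (going by the name of the read-out)), compound 1 `CC(C)=CCC/C(C)=C/CC1Cc2c(OCC=C(C)C)cc(=O)n(CCCO)c2CC1(C)C` gives 30.3%, compound 2 `CC(C)=CCC/C(C)=C/CC1Cc2c(OCCCNC(=O)c3cccs3)cc(=O)n(CCCO)c2CC1(C)C` gives 72.8% and compound 3 `COc1ccc(OCCCOc2cc(=O)n(CCCO)c3c2CC(C/C=C(\C)CCC=C(C)C)C(C)(C)C3)cc1` gives 20%, the lowest of the three. Compound 4 `COc1ccccc1NC(=O)Oc1cc(=O)n(CCCO)c2c1CC(C/C=C(\C)CCC=C(C)C)C(C)(C)C2` differs from compound 3 by (2-methoxyphenyl)carbamoyl in place of 3-(4-methoxyphenoxy)propyl on an oxygen on an aromatic ring. Two measured steps change the same oxygen: a number 10.3 percentage points lower from compound 1 to compound 3 (beyond the scatter) and a number 52.8 percentage points lower from compound 2 to compound 3 (beyond the scatter), so the number for the amide-bearing chain of compound 2 is far higher than those of both ether variants and the number for the aryl ether of compound 3 is the lowest of the three. For the measured compounds named here, compound 4 carries the (2-methoxyphenyl)carbamoyl, with its hydrogen-bond donor, on the aromatic-ring oxygen where compound 3 has a chain ether; no measured step covers this exact exchange, so only a partial rise is expected. The estimate for compound 4 is 45%, range 20% to 70%, with an expected step of a number 25 percentage points higher from compound 3 to compound 4 (beyond the scatter).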

Compound 4, a percentage reported as inhibition, at one concentration (the size of the read-out at that concentration, not a potency): 53%
Compound 4: middle estimate off by 8 percentage points, on the low side; low and high end bracket the measured number.
By their numbers in this assay, from the lowest: compound 3; then compound 1; then compound 4; then compound 2.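

In this assay the oxygen on the aromatic ring also carries a carbamoyl link with a high reading: the change gives a number 33 percentage points higher from compound 3 to compound 4 (beyond the scatter) and a number 22.7 percentage points higher from compound 1 to compound 4 (beyond the scatter) so (2-methoxyphenyl)carbamoyl stands above both ether variants. It still trails the thiophene amide chain, with a number 19.8 percentage points lower from compound 2 to compound 4 (beyond the scatter) and so the order of these four compounds places both nitrogen-bearing groups above both ethers. Nothing available explains these differences. Still open, going by these compounds, is what the methoxy on the carbamoyl phenyl contributes, and how a propyl chain ending in an amine or a carboxylic acid on this oxygen would read.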